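Amino to Methoxy: Estimating the Cytotoxicity of Compound 4

The source may report more compounds than this note shows. Statements on the series, on what has been measured and on what is new or still open speak of the compounds shown alone.

Compound 1, `COc1cc(C(=O)c2cn(-c3ccccc3)cc2-c2ccc(N)cc2)cc(OC)c1OC`: 9 nM
Compound 2, `COc1cc(C(=O)c2cn(-c3cccc(Br)c3)cc2-c2ccccc2)cc(OC)c1OC`: 78 nM
Compound 3, `COc1cc(C(=O)c2cn(-c3ccc(Cl)cc3)cc2-c2ccccc2)cc(OC)c1OC`: 140 nM

Of the compounds shown here, three sharing one core have been measured in a functional assay on MCF7 cells (Homo sapiens) for cytotoxicity, read by MTT assay, with a stated time of 96 h; on this read-out lower numbers stand for stronger inhibition and higher numbers for weaker inhibition. Compound 1 gives 9 nM, the lowest of the three numbers; compound 2 gives 78 nM and compound 3 gives 140 nM, both beyond the scatter from compound 1. Among the measured compounds shown here, the only single-site step among them, a 1.8-fold higher number from compound 2 to compound 3 (0.25 log units; within the scatter), concerns a change on the aromatic nitrogen and lies within the scatter.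

Compound 4, `COc1ccc(-c2cn(-c3ccccc3)cc2C(=O)c2cc(OC)c(OC)c(OC)c2)cc1`, has not yet been measured. It differs from compound 1 in one place: methoxy in place of amino on an aromatic carbon. For the measured compounds named here, no measured pair isolates this change; the step from compound 2 to compound 3 touches a different ring and does not bear on it. The data therefore give no ground for expecting a shift beyond the scatter in either direction, and the expectation rests on compound 1 alone, whose value is 9 nM.

Compound 4 is expected to give about 15 nM, within the range 3 nM to 70 nM. This estimate corresponds to an expected step of a 1.7-fold higher number from compound 1 to compound 4 (0.22 log units; within the scatter), a change within the scatter, because compound 1 gives 9 nM and nothing measured argues for a larger move.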

Compound 4, half-maximal inhibitory concentration: 70 nM
Compound 4: the middle estimate sits 4.7-fold (0.67 log units) below what was measured; the measured number falls inside the stated range.
By their numbers in this assay, from the lowest: compound 1; then compounds 4, 2 and 3 (each within the scatter of the next).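

In this assay, replacing amino with methoxy on an aromatic carbon gives a step beyond the scatter (a 7.8-fold higher number from compound 1 to compound 4 (0.89 log units; beyond the scatter)), which shows that this position on the shared core responds to the group it carries. Among the compounds shown here, the only step available earlier (a 1.8-fold higher number from compound 2 to compound 3 (0.25 log units; within the scatter)) concerned the group on the aromatic nitrogen and stayed within the scatter, so it gave no sign of such a response at any site. Here the exchange goes from amino, with 1 hydrogen-bond donor, to methoxy, with 0 hydrogen-bond donors, while each group has 1 hydrogen-bond acceptor, but no measurement at hand explains why the number rises.

Among the compounds differing in this one place, only amino and methoxy appear, so it remains open where a hydroxyl group, a dimethylamino group or a longer chain such as ethoxy would fall relative to compound 1 and compound 4. Whether the step from 4-aminophenyl to 4-methoxyphenyl would keep its size with 3-bromophenyl or 4-chlorophenyl on the aromatic nitrogen also stays unresolved.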